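The source may hold more compounds than are shown below. What is called first, only, known or untested is meant among the compounds shown, and "the series" means these compounds.

Measured so far:
Compound 1 `CC(C)c1ccc(-n2nc(-c3ccc(C(F)(F)F)cc3O)nc2-c2ccccc2O)cc1` gives 108% in a functional assay on PC-12 cells (Rattus norvegicus) for cytotoxicity, read by MTT assay, with stated times of 2 h and 24 h, tested at 10 uM; a lower number here means a weaker effect, a higher number a stronger effect of the compound at the concentration tested.
Compound 2 `CC(C)(C)c1ccc(-n2nc(-c3ccc(C(F)(F)F)cc3O)nc2-c2ccccc2O)cc1` gives 81.1% in this assay.
Compound 3 `Oc1cc(C(F)(F)F)ccc1-c1nc(-c2ccccc2O)n(-c2ccc(I)cc2)n1` gives 105% in this assay.

Compound 2 stands lowest of the three numbers in this assay; compound 3 is nearest, and compound 1 furthest, both beyond the scatter above it. The unmeasured compound 4 `Oc1cc(C(F)(F)F)ccc1-c1nc(-c2ccccc2O)n(-c2ccccc2F)n1` differs from compound 2 in one place: 2-fluorophenyl in place of 4-(tert-butyl)phenyl on an aromatic nitrogen.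

Going by the values given here, two measured steps bear on this change. Putting methyl in place of hydrogen on the saturated chain carbon moved the number a number 26.9 percentage points lower from compound 1 to compound 2 (beyond the scatter), and putting iodo in place of tert-butyl on the aromatic carbon moved it a number 23.9 percentage points higher from compound 2 to compound 3 (beyond the scatter); the step of a number 3 percentage points lower from compound 1 to compound 3 (within the scatter) shows that the number is little changed between isopropyl and iodo. Both measured departures from tert-butyl thus raise the number by a modest amount. The change to compound 4 also removes the tert-butyl group, so a modest upward step in this assay is expected, and the expected step is a number 18.9 percentage points higher from compound 2 to compound 4 (beyond the scatter). For compound 4 the estimate is 100%, with a range from 80% to 120%.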

Compound 4, a percentage reported as activity, at one concentration (the size of the read-out at that concentration, not a potency): 100%
The estimate for compound 4 equals the measured number at the digits printed, within the range that was stated.
By their numbers in this assay, from the lowest: compound 2; then compounds 4, 3 and 1 (each within the scatter of the next).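

In this assay the change on the aromatic nitrogen moves the number a number 18.9 percentage points higher from compound 2 to compound 4 (beyond the scatter) and so the low value of compound 2 stays tied to 4-(tert-butyl)phenyl alone among the groups shown. The number moves a number 5 percentage points lower from compound 3 to compound 4 (within the scatter) and a number 8 percentage points lower from compound 1 to compound 4 (within the scatter) so 2-fluorophenyl, 4-iodophenyl and 4-isopropylphenyl cannot be told apart here. The earlier compounds shown here left open whether a further departure from 4-(tert-butyl)phenyl would also hold the number up, and 2-fluorophenyl is one that does.

The compounds shown leave open how a plain phenyl, a 4-aminophenyl or a 4-carboxyphenyl on the aromatic nitrogen would read. They also leave open whether the fluorine of compound 4 contributes anything to its number. No measured evidence on the cause of these differences is available.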